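A few compounds are considered here, and "the series" means these few. Any claim that something is new, unique, unknown or untested is made for them only; others in the source may bear on it.

In a functional assay on FM3A cells (Mus musculus) for cytotoxicity (on this read-out higher numbers stand for an effect only at larger amounts of compound and lower numbers for an effect already at smaller amounts), compound 3 (`C=C(C)COOC1(OOC)CCCCCCCCCCC1`) gives 17000 nM. Compound 2 (`CCCCOOC1(OOCCCC)CCCCCCCCCCC1`) gives 8500 nM, within the usual scatter of compound 3, while compound 1 (`COOC1(OOC)CCCCCCCCCCC1`) gives 1500 nM. Compound 3 therefore stands well clear of compound 1 but cannot be separated from compound 2.

The change to compound 4 (`CCCCOOC1(OOC)CCCCCCCCCCC1`) is propyl in place of 1-methylethenyl on a saturated chain carbon bound to an oxygen on an unsaturated carbon. Cut one bond further out, butoxyoxy replaces ((2-methylprop-2-en-1-yl)oxy)oxy.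

One measured step acts at this place: an 11-fold higher number from compound 1 to compound 3 (1.05 log units; beyond the scatter), a large step with 1-methylethenyl in place of hydrogen. Within the data shown here, no measured step exchanges 1-methylethenyl for propyl directly, so the closest guide is compound 2 at 8500 nM, which also carries butoxyoxy. Compound 4 shares its saturated chain with compound 2 and the rest of its substitution with compound 1, so its number is expected to fall between those two values.

In this assay, a moderate move to a lower number is expected, read as a 2.8-fold lower number from compound 3 to compound 4 (0.45 log units; beyond the scatter). For compound 4, the estimated value is 6000 nM, with an expected range of 2000 nM to 17000 nM.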

Compound 4, half-maximal effective concentration: 20000 nM
Compound 4: middle estimate off by 3.3-fold (0.52 log units), on the low side, and the stated range ends below it.
By their numbers in this assay, from the lowest: compound 1; then compounds 2, 3 and 4 (each within the scatter of the next, the first and the last beyond it).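

In this assay, a 1.2-fold higher number from compound 3 to compound 4 (0.07 log units; within the scatter) shows that propyl and 1-methylethenyl cannot be told apart at this place, so the double bond outside aromatic rings makes no readable difference here. Read with an 11-fold higher number from compound 1 to compound 3 (1.05 log units; beyond the scatter), a 13-fold higher number from compound 1 to compound 4 (1.12 log units; beyond the scatter) shows that the large step on replacing hydrogen at this saturated chain carbon appears with both the unsaturated group and the saturated one. At the same time, a 2.4-fold higher number from compound 2 to compound 4 (0.37 log units; beyond the scatter) shows that butoxyoxy on the shared core does not give a steady climb: compound 4, with one butoxyoxy group, and compound 2, with two, are separated by a modest step, and compound 1 stays far from compound 4.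

From the compounds shown here alone, whether a longer chain, an amine or a carboxylic acid in place of propyl would keep the number in this high range remains open, as does how far the modest step from compound 2 to compound 4 extends to other groups. No supporting measurement bears on why the numbers fall this way.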